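Swapping a hydroxyl for a methoxy on the cyclohexyl arm

The compounds below may be only part of what the source reports. "The series", "measured", "known", "first", "only" and "open" are said of these compounds alone.

Compound 1 `COc1ccc(-c2c(-c3ccc(OC)cc3)n(Cc3ccccc3)c3ncn([C@@H]4CCCC[C@H]4O)c(=N)c23)cc1` carries a 2-hydroxycyclohexyl group on a ring nitrogen of its shared core. In an ADME assay for permeability, using PAMPA, with a stated time of 30 min, at pH 7.4 (on this read-out higher numbers stand for higher permeability and lower numbers for lower permeability), compound 1 gives > 1000 10^-6 cm/s, which is a limit of the assay rather than a measured number. Among the measured compounds shown here, compound 2 `COc1ccc(Cn2c(-c3ccccc3)c(-c3ccccc3)c3c(=N)n(CC4CCOCC4)cnc32)cc1` is the only member of the set with a plain number: in this assay compound 2 gives 1270 10^-6 cm/s. For compound 3 `N=c1c2c(-c3ccccc3)c(-c3ccccc3)n(CC3CCCCC3)c2ncn1[C@H]1CC[C@H](O)CC1` the read-out in this assay is "nd" (no result reported), so no result is available. Compound 1 thus sits at the top of what this set shows, as described by the limit of > 1000 10^-6 cm/s in this assay, at which 1 of the 3 values shown sits.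

Compound 4 `COc1ccc(-c2c(-c3ccc(OC)cc3)n(Cc3ccccc3)c3ncn([C@H]4CC[C@H](OC)CC4)c(=N)c23)cc1` differs from compound 1 in one place: 4-methoxycyclohexyl in place of 2-hydroxycyclohexyl on an aromatic nitrogen. For the measured compounds named here, no pair of measured compounds here differs in a single place, so the size of such a step cannot be read from the data. The expected step is a step that the limit leaves unreadable from compound 1 to compound 4, that is, nothing beyond the usual scatter, since compound 1 already stands at > 1000 10^-6 cm/s. Compound 4 is therefore estimated at 1400 10^-6 cm/s, with a likely range from 800 10^-6 cm/s to 2500 10^-6 cm/s, and the assay may again report only its limit.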

Compound 4, apparent permeability: > 1000 10^-6 cm/s
Compound 4 gave a limit, no number; the forecaster's own chance of this, stated with the estimate: 60%; the middle value does not contradict the limit.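

No step can be read from compound 1 to compound 4, since each gives only a limit rather than a number: the limit of > 1000 10^-6 cm/s in this assay, at which 2 of the 4 values shown sit.

The compounds shown leave open whether 4-methoxycyclohexyl in place of 2-hydroxycyclohexyl changes permeability at all, and by how much.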